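The source may report more compounds than this note shows. Statements on the series, on what has been measured and on what is new or still open speak of the compounds shown alone.

Measured in a functional assay on blood (Homo sapiens), with a stated time of 60 min, in the presence of a further agent that is not named here; a lower number here means that less compound is needed, a higher number that more compound is needed for the effect:
compound 1 `O=C(OCc1ccccc1)C1(S(=O)(=O)c2ccc(Oc3ccc(OC(F)(F)F)cc3)cc2)CCC2(CCNCC2)C1`: > 15000 nM (a limit)
compound 2 `O=S(=O)(c1ccc(Oc2ccc(OC(F)(F)F)cc2)cc1)C1(CO)CCC2(CCNCC2)C1`: > 15000 nM (a limit)
compound 3 `Nc1ccccc1NC(=O)C1(S(=O)(=O)c2ccc(Oc3ccc(OC(F)(F)F)cc3)cc2)CCC2(CCNCC2)C1`: 900 nM

Among the compounds with values here, compound 3 gives the only number in the set. Compound 1 and compound 2 both stand at the limit of > 15000 nM in this assay, at which 2 of the 3 values shown sit.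

Compound 4 `CS(=O)(=O)NC(=O)C1(S(=O)(=O)c2ccc(Oc3ccc(OC(F)(F)F)cc3)cc2)CCC2(CCNCC2)C1` carries methylsulfonyl in place of 2-aminophenyl on an amide-type nitrogen. Within the data shown here, two measured steps bear on this: an at least 16-fold lower number from compound 1 to compound 3 (1.22 log units; beyond the scatter) and an at least 16-fold lower number from compound 2 to compound 3 (1.22 log units; beyond the scatter). Both are large, and each brings in the 2-aminophenyl group that compound 4 loses. Among the measured compounds shown here, no measured compound carries methylsulfonyl, so the expectation is indirect. A large move to a higher number in this assay is expected, and a result reported only as a limit is quite possible. The expected size is an 8.9-fold higher number from compound 3 to compound 4 (0.95 log units; beyond the scatter). For compound 4 the estimate is 8000 nM, with an expected range from 2000 nM to 30000 nM.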

Compound 4, half-maximal effective concentration: > 15000 nM
Compound 4 was reported as a limit; the forecaster's own chance of this, stated with the estimate: 50%; middle value at least 1.8-fold (0.27 log units) away from the limit.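

In this assay, methylsulfonyl in place of 2-aminophenyl on the amide-type nitrogen gives an at least 16-fold higher number from compound 3 to compound 4 (1.22 log units; beyond the scatter). The earlier steps shown here replaced the whole group on the carbonyl carbon or the saturated ring carbon, whereas this one keeps the amide-type nitrogen, so that nitrogen on the carbonyl carbon does not by itself give a measurable number here. The steps among compound 1, compound 2 and compound 4 cannot be read: the limit of > 15000 nM in this assay, at which 3 of the 4 values shown sit.

Still open, on these data alone, is which part of 2-aminophenyl matters, its ring or its amine. A plain phenyl group on the same nitrogen would separate the two.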